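Aminomethyl to Ester: Expected Solubility of Compound 4

The source may report more compounds than this note shows. Statements on the series, on what has been measured and on what is new or still open speak of the compounds shown alone.

Compound 3 `Cc1cc(CCC#N)cc(C)c1Oc1cc(Nc2ccc(C#N)cc2)c(N)cc1CNC1CC1` gives the highest number of the three compounds in a physicochemical assay for solubility, read by HPLC, with a stated time of 4 h, at pH 2, tested at 10 mg/mL (on this read-out lower numbers stand for lower solubility and higher numbers for higher solubility), at 276 ug/mL. Compound 2 `Cc1cc(CCC#N)cc(C)c1Oc1cc(Nc2ccc(C#N)cc2)c(N)cc1CN(C)C` gives 260 ug/mL, and the pair differ by a 1.1-fold higher number from compound 2 to compound 3 (0.03 log units; within the scatter). Compound 1 `Cc1cc(CCC#N)cc(C)c1Oc1cc(Nc2ccc(C#N)cc2)c(N)cc1C(=O)N(C)C` gives 65.1 ug/mL, the lowest of the three, since the steps of a 4.0-fold higher number from compound 1 to compound 2 (0.60 log units; beyond the scatter) and a 4.2-fold higher number from compound 1 to compound 3 (0.63 log units; beyond the scatter) are both beyond the scatter. Compound 4 `Cc1cc(CCC#N)cc(C)c1Oc1cc(Nc2ccc(C#N)cc2)c(N)cc1COC(=O)C1CC1` differs from compound 3 in one place: (cyclopropylcarbonyl)oxy in place of cyclopropylamino on a saturated chain carbon bound to an aromatic carbon. Within the data shown here, no measured step carries this exact change, but the two steps from compound 1 bear on it: in each, a group holding a nitrogen in a saturated chain replaced a carbonyl-bearing group, and the number rose. The change to compound 4 runs the other way, removing the nitrogen and the hydrogen-bond donor and bringing in a carbonyl. The step is therefore expected to be downward, roughly reversing the size of a 4.2-fold higher number from compound 1 to compound 3 (0.63 log units; beyond the scatter), giving an estimated 6.9-fold lower number from compound 3 to compound 4 (0.84 log units; beyond the scatter) in this assay. Compound 4 is expected to show about 40 ug/mL, with a range from 12 ug/mL to 130 ug/mL.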

Compound 4, solubility: 1.24 ug/mL
For compound 4 the middle estimate is 32-fold (1.51 log units) above the measured one; measured number outside the range, below it.
By their numbers in this assay, from the lowest: compound 4; then compound 1; then compounds 2 and 3 (each within the scatter of the next).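

In this assay, (cyclopropylcarbonyl)oxy in place of cyclopropylamino on a saturated chain carbon bound to an aromatic carbon gives a 220-fold lower number from compound 3 to compound 4 (2.35 log units; beyond the scatter), and in place of dimethylamino it gives a 210-fold lower number from compound 2 to compound 4 (2.32 log units; beyond the scatter). The number does not stop near that of the dimethylcarbamoyl compound, as ((cyclopropylcarbonyl)oxy)methyl in its place gives a 53-fold lower number from compound 1 to compound 4 (1.72 log units; beyond the scatter), so this position spans a far wider range than the earlier 4.2-fold higher number from compound 1 to compound 3 (0.63 log units; beyond the scatter) had shown. No measurement shown here accounts for the size of this fall.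

The compounds shown leave open whether the fall follows the loss of the nitrogen or the entry of the (cyclopropylcarbonyl)oxy group, as both happen in one change. A hydroxymethyl or a (cyclopropylmethoxy)methyl group at the same aromatic carbon would separate the two.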